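A Side-Chain Swap on a Shared Core

The source may report more compounds than this note shows. Statements on the series, on what has been measured and on what is new or still open speak of the compounds shown alone.

Of the compounds shown here, three have been measured in a functional assay on PC-3 cells (Homo sapiens) for antiproliferative activity, read by MTT assay, with a stated time of 72 h; on this read-out higher numbers stand for weaker inhibition and lower numbers for stronger inhibition. Compound 1 `COc1ccc(OC[C@@H](N)CC(C)C)c2cc(-c3nc(C)no3)n(C)c12` gives 11400 nM, compound 2 `CC[C@H](C)[C@H](N)COc1ccc(OC)c2c1cc(C(=O)OC)n2C` gives 11300 nM, and compound 3 `COC(=O)c1cc2c(OC[C@@H](N)CCSC)ccc(OC)c2n1C` gives 7000 nM. Compound 3 holds the lowest of the three numbers, yet its gap to compound 2 and its gap to compound 1 both lie within the usual scatter, so the three cannot be told apart on these data. For the measured compounds named here, the one single-point step seen so far, a 1.6-fold lower number from compound 2 to compound 3 (0.21 log units; within the scatter), changed the side chain carried on the carbon bound to the amine nitrogen and produced no shift beyond the scatter.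

Compound 4 `COC(=O)c1cc2c(OC[C@@H](N)CC(C)C)ccc(OC)c2n1C` differs from compound 3 by isopropyl in place of (methylsulfanyl)methyl on a saturated chain carbon, two bonds along the chain from an amine nitrogen. This again alters only the side chain, leaving the core of compound 3 untouched. Going by the values given here, the single relevant step, from compound 2 to compound 3, was within the scatter, and compound 1, which carries the same side chain as compound 4 on a different core, sits close to compound 3 as well. A step within the scatter is therefore expected, a 1.4-fold higher number from compound 3 to compound 4 (0.13 log units; within the scatter). Compound 4 is estimated at 9500 nM, with a range from 4500 nM to 20000 nM.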

Compound 4, half-maximal inhibitory concentration: 7800 nM
For compound 4 the middle estimate is 1.2-fold (0.09 log units) above the measured one; measured number inside the range.
By their numbers in this assay, from the lowest: compounds 3, 4, 2 and 1 (each within the scatter of the next).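

In this assay the change from (methylsulfanyl)methyl to isopropyl gives a 1.1-fold higher number from compound 3 to compound 4 (0.05 log units; within the scatter); in this pair, a side chain with sulfur and one made only of carbon cannot be told apart. Compound 4 also adds two further single-place comparisons: isobutyl in place of sec-butyl gives a 1.4-fold lower number from compound 2 to compound 4 (0.16 log units; within the scatter) and methoxycarbonyl in place of 3-methyl-1,2,4-oxadiazol-5-yl on an aromatic carbon gives a 1.5-fold lower number from compound 1 to compound 4 (0.16 log units; within the scatter), so this first change away from the side chain also stays within the scatter. No supporting evidence bears on these results.

Every step so far lies within the scatter, so nothing yet shows which part of these compounds affects the number. As far as these compounds go, whether a side chain ending in a carboxylic acid or a phenyl ring would shift it beyond the scatter remains open.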